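The compounds below may be only part of what the source reports. "The series", "measured", "known", "first", "only" and "open" are said of these compounds alone.

Compounds measured in an assay on Cortex for displacement of a labelled ligand from Voltage-dependent L-type calcium channel subunit alpha-1D (Rattus norvegicus); on this read-out higher numbers stand for weaker inhibition and lower numbers for stronger inhibition:
- compound 1, `COC(=O)C1=C(C)N=C(C)/C(=C(/O)OC)C1c1cccc(OCc2nonc2C)c1`: 320 nM
- compound 2, `COC(=O)C1=C(C)N=C(C)/C(=C(/O)OC)C1c1ccccc1OCc1nonc1C`: 27 nM

Of the two measured compounds, compound 2 gives the lower number in this assay, and the gap to compound 1 lies beyond the usual scatter of repeated measurements, so compound 2 stands as the stronger inhibitor of the pair. Both share the same core; they differ only in where the (4-methyl-1,2,5-oxadiazol-3-yl)methoxy group is attached on the phenyl ring.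

Compound 3, `COC(=O)C1=C(C)N=C(C)/C(=C(/O)OC)C1c1ccccc1OCc1nonc1C(N)=O`, has not yet been measured in this assay. It differs from compound 2 in one place: carbamoyl in place of methyl on an aromatic carbon. Within the data shown here, no measured pair shows the effect of this change, so its size and direction cannot be read from the data at hand. The attachment pattern that distinguishes compound 2 from compound 1 is kept in compound 3, which is the main ground for expecting compound 3 to stay nearer to compound 2 than to compound 1. A step of moderate size, on the side of a higher number, is expected from compound 2 to compound 3, a 2.2-fold higher number from compound 2 to compound 3 (0.35 log units; beyond the scatter). Compound 3 is therefore estimated at 60 nM, within a range from 15 nM to 250 nM.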

Compound 3, inhibition constant: 400 nM
For compound 3 the middle estimate is 6.7-fold (0.82 log units) below the measured one; the whole stated range lies below it.
By their numbers in this assay, from the lowest: compound 2; then compounds 1 and 3 (each within the scatter of the next).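

In this assay, carbamoyl in place of methyl on an aromatic carbon of the five-membered aromatic ring, next to the ring atom that bears a large group, gives a 15-fold higher number from compound 2 to compound 3 (1.17 log units; beyond the scatter), a large step and the first sign that this ring position affects the read-out. Compounds 1 and 2 showed only that the attachment point on the phenyl ring matters, whereas compound 3 shows that keeping the attachment pattern of compound 2 does not by itself preserve its low number, and that the methyl cannot be exchanged for carbamoyl without a clear loss of inhibition. No available measurement explains this loss.

Going by these compounds, with only methyl and carbamoyl at this ring carbon, it remains open how a hydrogen, an ethyl group, a nitrile or a carboxylic acid would read there, and so whether the step follows the added heavy atoms or the entering hydrogen-bond donor and acceptor. On these data alone, it is also open whether the same exchange would shift the number similarly with the side chain attached to the phenyl ring as in compound 1.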